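The compounds below may be only part of what the source reports. "The series", "measured", "known", "first", "only" and "open" are said of these compounds alone.

Measured compounds:
compound 1 `C[C@H](Nc1ncnc2[nH]cnc12)c1cc2ccccn2c(=O)c1-c1ccccc1` — 93%
compound 2 `Cc1cccc2cc([C@H](C)Nc3ncnc4[nH]cnc34)c(-c3ccccc3)c(=O)n12` — 73%

In an ADME assay on microsomes from liver (Rattus norvegicus), read by LC-MS, using NADPH, with a stated time of 30 min, tested at 1 uM (on this read-out higher numbers stand for a more stable compound and lower numbers for a less stable compound), compound 1 gives 93%, the highest of the two numbers. Its nearest neighbour, compound 2, gives 73%, a step of a number 20 percentage points lower from compound 1 to compound 2 (beyond the scatter) for a methyl in place of hydrogen on an aromatic carbon. Compound 3 `C[C@H](Nc1ncnc2[nH]cnc12)c1cc2ccc(F)cn2c(=O)c1-c1ccccc1` is not yet measured; it differs from compound 1 by fluoro in place of hydrogen on an aromatic carbon. Among the measured compounds shown here, the only measured step, that from compound 1 to compound 2, concerns a methyl rather than a fluoro and bears on the present change only loosely; it shows that a single substituent on this ring can lower the read-out modestly. Compound 3 is therefore expected to stay close to compound 1 and give about 85%, within 65% to 98%. The estimated step is a number 8 percentage points lower from compound 1 to compound 3 (within the scatter), most likely within the scatter or a small loss beyond it.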

Compound 3, percent of the compound remaining: 95%
For compound 3 the middle estimate is 10 percentage points below the measured one; the range from low to high includes it.
By their numbers in this assay, from the lowest: compound 2; then compounds 1 and 3 (each within the scatter of the next).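

In this assay, fluoro on this aromatic carbon, two atoms from the ring nitrogen, leaves the read-out of the core of compound 1 effectively unchanged (a number 2 percentage points higher from compound 1 to compound 3 (within the scatter)). The earlier step (a number 20 percentage points lower from compound 1 to compound 2 (beyond the scatter)) showed a loss for methyl at a different aromatic carbon of the same ring, so this result shows that a substituent on this ring does not always come with a loss. No measurement at hand bears on why the two steps part ways.

The compounds shown do not separate the effect of the position from that of the group, since methyl and fluoro sit at different carbons. Going by these compounds, how a methyl, a methoxy group or an amine would fare on the carbon that carries fluoro in compound 3, and how fluoro would fare where compound 2 carries its methyl, stays open.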